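The source may report more compounds than this note shows. Statements on the series, on what has been measured and on what is new or still open speak of the compounds shown alone.

Measured compounds:
Compound 1, `COc1ccc2nc(NC3CCCCC3)c(S(C)(=O)=O)nc2c1`, gives in an ADME assay on HepG2 cells (Homo sapiens) for cytotoxicity, read by CellTiter-Glo, with a stated time of 48 h (a lower number here means that less compound is tolerated, a higher number that more compound is tolerated), a value of 12600 nM.
Compound 2, `CS(=O)(=O)c1nc2ccc(Cl)cc2nc1NC1CCCCC1`, gives in this assay a value of 5010 nM.
Compound 3, `COc1ccc2nc(NC3CCCCC3)c([S+](C)[O-])nc2c1`, gives in this assay a value of 12600 nM.

Compound 3 differs from compound 1 in one place: a group of 3 heavy atoms (1 carbon, 1 oxygen, 1 sulfur; no ring) in place of a group of 4 heavy atoms (1 carbon, 2 oxygen, 1 sulfur; no ring), on an aromatic carbon. This change produced no change at the digits printed from compound 1 to compound 3 (within the scatter). Compound 2 carries a different core from compound 1; the difference between the two cores is not broken down here. Of the three measured compounds, compound 2 stands lowest in this assay, and its gap to each of the other two lies beyond the usual scatter.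

Compound 4, `C[S+]([O-])c1nc2ccc(Cl)cc2nc1NC1CCCCC1`, has not yet been measured. It differs from compound 2 by a group of 3 heavy atoms (1 carbon, 1 oxygen, 1 sulfur; no ring) in place of a group of 4 heavy atoms (1 carbon, 2 oxygen, 1 sulfur; no ring), on an aromatic carbon. The surroundings of the change are described in the same words as for the change from compound 1 to compound 3, so it is the same change on the second core. On the basis of no change at the digits printed from compound 1 to compound 3 (within the scatter), the step from compound 2 to compound 4 in this assay is expected to be a 1.0-fold lower number from compound 2 to compound 4 (0.00 log units; within the scatter). Compound 4 is therefore estimated to give 5000 nM in this assay, with an expected range from 2500 nM to 10000 nM.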

Compound 4, half-maximal cytotoxic concentration: 15900 nM
Beside the measured number, compound 4's estimate is 3.2-fold (0.50 log units) below it, outside the stated range (above it).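

On the core of compound 2, the same replacement of the methylsulfonyl group gave a 3.2-fold higher number from compound 2 to compound 4 (0.50 log units; beyond the scatter) in this assay, so a result read on the core of compound 1 did not carry over to this second core. The two cores answer differently to this one change: the same change on two cores in this assay, no change at the digits printed (within the scatter) from compound 1 to compound 3 and a 3.2-fold higher number (0.50 log units; beyond the scatter) from compound 2 to compound 4, 3.2-fold (0.50 log units) apart, beyond the scatter of two such steps This rests on a single pair on each core, so it shows that the change cannot be assumed to transfer within this series, but it does not show what in the cores sets the two steps apart, nor how a third core would respond.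

The compounds shown leave open how other groups would behave on this aromatic carbon, such as a methylthio group, a carboxylic acid or an amine, and whether they too would depend on the core. On these data alone, it also remains open whether the same difference between the two cores would appear with a longer alkyl chain in place of the cyclohexylamino group.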